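Swapping the Furan of Compound 1 for a Larger Ring

This account rests on a few compounds, and the source may have more. Where it says the series, first, only, none or still open, it means among the compounds named here.

Compound 1 `COC(=O)C(C)(O)[C@](O)(C[C@H](C)CCC/C(C)=C/CC/C(C)=C/CCc1ccoc1)C(=O)OC` is the more toxic of the two measured compounds: in a functional assay on K562 cells (Homo sapiens) for cytotoxicity, read by MTT assay (on this read-out higher numbers stand for lower toxicity in this test and lower numbers for higher toxicity in this test), compound 1 gives 20 ug/mL, while compound 2 `COC(=O)C(C)(O)[C@@](O)(C[C@H](C)CC/C=C(/C)CC/C=C(/C)CCCc1ccoc1)C(=O)OC` gives 46 ug/mL, a gap beyond the usual scatter. Compound 3 `COC(=O)C(C)(O)[C@](O)(C[C@H](C)CCC/C(C)=C/CC/C(C)=C/CCC1=CCN(CC(=O)O)C1=O)C(=O)OC` has not been measured. It differs from compound 1 by a group of 10 heavy atoms (6 carbon, 1 nitrogen, 3 oxygen; one five-membered non-aromatic ring with 1 hetero atom) in place of a group of 5 heavy atoms (4 carbon, 1 oxygen; one five-membered aromatic ring with 1 hetero atom), on a saturated chain carbon, two bonds along the chain from a double-bonded chain carbon. Among the measured compounds shown here, no measured pair shows such a swap, so the expectation rests on the structures alone: a modest step toward a higher number, a 1.8-fold higher number from compound 1 to compound 3 (0.24 log units; within the scatter), is expected, since the measured values of compound 1 and compound 2 both lie in a narrow band. Compound 3 is estimated at 35 ug/mL, within 12 ug/mL to 100 ug/mL.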

Compound 3, concentration lethal to 50% of the cells: > 100 ug/mL
Compound 3 was reported as a limit; the forecaster's own chance of this, stated with the estimate: 15%; at least 2.8-fold (0.45 log units) between middle value and limit.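

At this saturated chain carbon the group is not a neutral spot: putting the larger non-aromatic ring in place of furan-3-yl gives an at least 5.0-fold higher number from compound 1 to compound 3 (0.69 log units; beyond the scatter) in this assay, which points to lower toxicity in this test. The earlier compounds shown here carried furan-3-yl throughout, so they could not show this. The reading for compound 3 is a limit, not a number: the limit of > 100 ug/mL in this assay, at which 1 of the 3 values shown sits.

From the compounds shown here alone, the full size of the step stays open, and the swap changes ring, size and donor count at once, so no single feature can be singled out. Going by these compounds, whether a phenyl ring or an amine at this place would behave like furan-3-yl also stays open.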